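This account rests on a few compounds, and the source may have more. Where it says the series, first, only, none or still open, it means among the compounds named here.

Values so far in an ADME assay on microsomes from liver (Homo sapiens) for metabolic stability; a higher number here means that the compound lasts longer, a lower number that the compound disappears faster:

Compound 1 `NS(=O)(=O)CC(=O)NCCSc1nonc1/C(=N/O)Nc1cccc(C(F)F)c1` gives > 3 h (a limit of the assay)
Compound 2 `NS(=O)(=O)CC(=O)NCCSc1nonc1/C(=N/O)Nc1ccc(F)c(C(F)F)c1` gives 2.77 h
Compound 3 `CC1(C(=O)NCCSc2nonc2/C(=N/O)Nc2ccc(F)c(C(F)F)c2)CCN1` gives 1.97 h

Compound 3 lies within the scatter of compound 2, so the two cannot be ordered. The reading for compound 1 is only a limit.

The next compound is compound 4 `O=C(NCCSc1nonc1/C(=N/O)Nc1ccc(F)c(C(F)F)c1)C1CS(=O)(=O)C1`. It differs from compound 3 on a carbonyl carbon whose other neighbour is an amide-type nitrogen (a group of 6 heavy atoms (3 carbon, 2 oxygen, 1 sulfur; one four-membered non-aromatic ring with 1 hetero atom) in place of a group of 5 heavy atoms (4 carbon, 1 nitrogen; one four-membered non-aromatic ring with 1 hetero atom), on a carbonyl carbon).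

Among the compounds with values here, the closest precedent is the exchange at the same carbonyl carbon, a 1.4-fold lower number from compound 2 to compound 3 (0.15 log units; within the scatter). The fluoro exchange elsewhere in the series, an at least 1.0-fold lower number from compound 1 to compound 2 (0.03 log units; that floor lies within the scatter), gives only a floor, also within the scatter. Within the data shown here, with compound 3 as the starting point and the exchange a 1.4-fold lower number from compound 2 to compound 3 (0.15 log units; within the scatter) as the only guide at this carbon, no step beyond the scatter is expected in this assay.

The expected step is a 1.2-fold higher number from compound 3 to compound 4 (0.09 log units; within the scatter).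

Compound 4 is estimated at 2.4 h, with an expected range of 1.3 h to 3.8 h.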

Compound 4, half-life: 1.28 h
Compound 4: middle estimate off by 1.9-fold (0.27 log units), on the high side; measured number below the stated range.
By their numbers in this assay, from the lowest: compounds 4, 3 and 2 (each within the scatter of the next, the first and the last beyond it). At a limit, above all of these: compound 1.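

In this assay, within the data shown here, an exchange on the carbonyl carbon whose other neighbour is the amide-type nitrogen gives a modest step beyond the scatter for the first time in these notes, with a 2.2-fold lower number from compound 2 to compound 4 (0.34 log units; beyond the scatter). The step between the two groups that each carry a four-membered non-aromatic ring stays within the scatter, with a 1.5-fold lower number from compound 3 to compound 4 (0.19 log units; within the scatter), so those two groups cannot be ordered and only the open-chain group and the group of 6 heavy atoms are separated. Nothing at hand bears on why this exchange shortens the half-life.

From the compounds shown here alone, whether an open-chain amine or a carboxylic acid on this carbonyl carbon would track compound 2 or compound 4 stays open. Going by these compounds, compound 1 gives > 3 h, which is a limit, so the size of the fluoro exchange also stays open.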